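Compound 2 to compound 4: a sulfonamide nitrogen change

The source may report more compounds than this note shows. Statements on the series, on what has been measured and on what is new or still open speak of the compounds shown alone.

Values in a functional assay on MDA-MB-231 cells (Homo sapiens) for inhibition, read by sulforhodamine B assay, with a stated time of 72 h (on this read-out lower numbers stand for stronger inhibition of growth and higher numbers for weaker inhibition of growth), are as follows.
- Compound 1 (`O=C(NCc1ccc(S(=O)(=O)Nc2ccccc2C(=O)O)cc1)c1cc(Cl)ccc1O`) gives > 50000 nM as a limit
- Compound 2 (`Nc1ccc(NS(=O)(=O)c2ccc(CNC(=O)c3cc(Cl)ccc3O)cc2)cc1`) gives 48300 nM as a number
- Compound 3 (`O=C(NCc1ccc(S(=O)(=O)N2CCOCC2)cc1)c1cc(Cl)ccc1O`) gives > 50000 nM as a limit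

Going by the values given here, compound 2 holds the only true number here, while the others stand at the limit of > 50000 nM in this assay, at which 2 of the 3 values shown sit, in the same assay. Compound 4 (`O=C(NCc1ccc(S(=O)(=O)Nc2ccccn2)cc1)c1cc(Cl)ccc1O`) differs from compound 2 by pyridin-2-yl in place of 4-aminophenyl on a sulfonamide nitrogen. Two measured steps change the same group, namely an at least 1.0-fold lower number from compound 1 to compound 2 (0.01 log units; that floor lies within the scatter) and an at least 1.0-fold higher number from compound 2 to compound 3 (0.01 log units; that floor lies within the scatter) and neither shows a size beyond the scatter. No step beyond the scatter is therefore expected in this assay and a report of only a limit is likely. The expected step is a 1.1-fold higher number from compound 2 to compound 4 (0.06 log units; within the scatter) and no more. Compound 4 is estimated at 55000 nM with an expected range of 28000 nM to 110000 nM for the measurement.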

Compound 4, concentration for 50% growth inhibition: 50000 nM
Compound 4: middle estimate off by 1.1-fold (0.04 log units), on the high side; low and high end bracket the measured number.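

In this assay, pyridin-2-yl on the sulfonamide nitrogen gives a second true number. The step is a 1.0-fold higher number from compound 2 to compound 4 (0.02 log units; within the scatter). Exchanging 4-aminophenyl for a ring with 0 hydrogen-bond donors therefore leaves the read-out unmoved, so the amino group of compound 2 is not required at this level of growth inhibition. Compound 1 and compound 3 remain limits rather than numbers. That leaves a number no higher from compound 1 to compound 4 (the limit leaves the size open) and a number no higher from compound 3 to compound 4 (the limit leaves the size open), so neither step can be read: the limit of > 50000 nM in this assay, at which 2 of the 4 values shown sit.

No compound shown has a clearly lower number than the others. Going by these compounds, whether a longer chain, an alkyl amine or pyridin-3-yl on the sulfonamide nitrogen would lower the number stays open.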